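The source may hold more compounds than are shown below. What is called first, only, known or untested is meant among the compounds shown, and "the series" means these compounds.

Compound 2 `CCCCCCCCCCn1c(N2CCN(C)CC2)nc2ccccc21` gives 4200 nM in a functional assay on ileum for inhibition of histamine H1 receptor (Cavia porcellus) (a lower number here means a stronger inhibitor, a higher number a weaker inhibitor), the highest of the two numbers recorded so far; its nearest neighbour, compound 1 `C#CCOCCn1c(N2CCN(C)CC2)nc2ccccc21`, gives 12 nM. Among the measured compounds shown here, the only measured step, a 350-fold higher number from compound 1 to compound 2 (2.54 log units; beyond the scatter), joins these two compounds and shows how much the number rises when the octyl group replaces the propargyloxy group on a saturated chain carbon, two bonds along the chain from an aromatic nitrogen.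

Compound 3 `CC(C)CCn1c(N2CCN(C)CC2)nc2ccccc21` keeps the shared core of compound 2 and differs from it only here: isopropyl in place of octyl on a saturated chain carbon, two bonds along the chain from an aromatic nitrogen. That step removes most of the octyl chain but brings back no propargyloxy group, so the measured step bears on it only in part. A lower number is expected for compound 3, of moderate size, because a 350-fold higher number from compound 1 to compound 2 (2.54 log units; beyond the scatter) showed that the long chain went together with a much higher number; the estimated step is an 11-fold lower number from compound 2 to compound 3 (1.02 log units; beyond the scatter), giving compound 3 an expected 400 nM with a range from 50 nM to 3000 nM.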

Compound 3, half-maximal inhibitory concentration: 1400 nM
Compound 3: middle estimate off by 3.5-fold (0.54 log units), on the low side; measured number inside the range.
By their numbers in this assay, from the lowest: compound 1; then compound 3; then compound 2.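

In this assay, the change from octyl to isopropyl gives a 3.0-fold lower number from compound 2 to compound 3 (0.48 log units; beyond the scatter) and so closes only a small part of the gap to compound 1, while the change from propargyloxy to isopropyl still gives a 120-fold higher number from compound 1 to compound 3 (2.07 log units; beyond the scatter) and remains large. On a saturated chain carbon, two bonds along the chain from an aromatic nitrogen, removing most of the octyl chain therefore does not bring the number back to that of compound 1, and compound 2 and compound 3 stand much closer to each other than either does to compound 1. No measurement at hand accounts for this difference.

The compounds shown leave open which part of the propargyloxy group goes with the low number of compound 1, the ether oxygen or the alkyne. A methoxy or a propoxy group in this place would help to separate the two.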